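Swapping the five-membered ring on a shared core

The source may hold more compounds than are shown below. What is called first, only, known or untested is meant among the compounds shown, and "the series" means these compounds.

Two compounds share one core and differ only in the small aromatic ring attached to it. Compound 1 `Cc1cc2nc(-c3nccs3)n(-c3ccc4c(N)nc(N)nc4c3)c2cc1C` carries a 1,3-thiazol-2-yl group there, and in an assay on isolated protein for inhibition of Dihydrofolate reductase (Homo sapiens), read by spectrophotometry, using NADPH, with a stated time of 10 min (a higher number here means a weaker inhibitor, a lower number a stronger inhibitor), compound 1 gives 93 nM. Compound 2 `Cc1cc2nc(-c3cncn3C)n(-c3ccc4c(N)nc(N)nc4c3)c2cc1C` carries a 1-methyl-1H-imidazol-5-yl group instead, and in this assay compound 2 gives 2920 nM, the highest of the two numbers; its nearest neighbour is compound 1, and the step of a 31-fold higher number from compound 1 to compound 2 (1.50 log units; beyond the scatter) lies beyond the scatter.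

Compound 3 `Cc1cc2nc(-c3cccn3C)n(-c3ccc4c(N)nc(N)nc4c3)c2cc1C` has not yet been measured. Relative to compound 2 the change is 1-methyl-1H-pyrrol-2-yl in place of 1-methyl-1H-imidazol-5-yl on an aromatic carbon. Going by the values given here, the only measured step that bears on this position is the one from compound 1 to compound 2, which was large. It involved a different pair of rings, so it shows that this position is sensitive but gives no direct guide to direction. Some step beyond the scatter in this assay is therefore plausible, with a wide range. Compound 3 is expected to give about 1500 nM, within 300 nM to 8000 nM, an estimated step of a 1.9-fold lower number from compound 2 to compound 3 (0.29 log units; within the scatter).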

Compound 3, inhibition constant: > 5000 nM
Compound 3: a limit, no number; the forecaster's own chance of this, stated with the estimate: 5%; middle value at least 3.3-fold (0.52 log units) from the limit.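

In this assay compound 3 gives no number, only a limit: the limit of > 5000 nM in this assay, at which 1 of the 3 values shown sits.

Read against the 1-methyl-1H-imidazol-5-yl group, the 1-methyl-1H-pyrrol-2-yl group gives an at least 1.7-fold higher number from compound 2 to compound 3 (0.23 log units; that floor lies within the scatter), so this limit cannot tell whether the two rings truly differ, or by how much. Read against the 1,3-thiazol-2-yl group, the same limit gives an at least 53-fold higher number from compound 1 to compound 3 (1.73 log units; beyond the scatter), which is beyond the scatter even at its floor, so a second methyl-bearing ring, this one with a single hetero atom, also falls well short of compound 1, which remains the strongest of the three.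

The compounds shown leave open whether the loss follows the methyl group on the ring nitrogen, which compound 2 and compound 3 both carry, or the identity of the ring itself. A plain phenyl ring or a 1H-imidazol-5-yl group without that methyl, placed on the same aromatic carbon of the shared core, would help to separate these two readings.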